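The compounds below may be only part of what the source reports. "The series", "measured", "known", "first", "only" and "open" are said of these compounds alone.

Compound 1 `COc1cc(-c2nc3ccccc3s2)ccc1OCC(=O)NNC(O)CN(C)CC(=O)O`: 3030 nM
Compound 2 `COc1cc(-c2nc3ccccc3s2)ccc1OCC(=O)NNC(=O)CNC(=N)NCCC[C@H](N[N+](=O)[O-])C(=O)O`: 3490 nM
Compound 3 `COc1cc(-c2nc3ccccc3s2)ccc1OCC(=O)NNC(=O)CN1CCC[C@H]1C(=O)O`: 2650 nM

In a functional assay on HepG2 cells (Homo sapiens) for inhibition, read by MTT assay, with a stated time of 3 days (on this read-out lower numbers stand for stronger inhibition and higher numbers for weaker inhibition), compound 3 gives 2650 nM, within the scatter of compound 1 and compound 2. Next comes compound 4 `CCOC(=O)[C@H](CS(=O)(=O)O)NCC(=O)NNC(=O)COc1ccc(-c2nc3ccccc3s2)cc1OC`: (1-(ethoxycarbonyl)-2-sulfoethyl)amino in place of 2-carboxypyrrolidin-1-yl on a saturated chain carbon bound to a carbonyl carbon. In words, (1-(ethoxycarbonyl)-2-sulfoethyl)amino stands in place of 2-carboxypyrrolidin-1-yl on a saturated chain carbon bound to a carbonyl carbon. Among the compounds with values here, the one measured step bearing on this is a 1.1-fold lower number from compound 1 to compound 3 (0.06 log units; within the scatter). Compound 2, with yet another chain on the shared core, gives 3490 nM. Within the data shown here, no measured compound carries the entering group, so the evidence is thin. In this assay no step beyond the scatter is expected, in either direction. The estimated move is a 1.1-fold higher number from compound 3 to compound 4 (0.05 log units; within the scatter). For compound 4 the expected value is 3000 nM, with an estimated range of 1500 nM to 6500 nM.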

Compound 4, half-maximal inhibitory concentration: 3360 nM
For compound 4 the middle estimate is 1.1-fold (0.05 log units) below the measured one, and the stated range covers the measured number.
By their numbers in this assay, from the lowest: compounds 3, 1, 4 and 2 (each within the scatter of the next).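

In this assay, a 1.3-fold higher number from compound 3 to compound 4 (0.10 log units; within the scatter). On a saturated chain carbon bound to a carbonyl carbon, the ring of 2-carboxypyrrolidin-1-yl can therefore give way to the ringless (1-(ethoxycarbonyl)-2-sulfoethyl)amino, with 12 heavy atoms in place of 8 and a sulfur atom entering, without a step beyond the scatter. No supporting data bear on why this change leaves the read-out within the scatter.

Open, on these data alone, is whether a plain dimethylamino or piperidin-1-yl group at this place, lacking any acid or ester, would stay within the scatter.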